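A Hydroxy Addition Repeated on a Second Core

A few compounds are considered here, and "the series" means these few. Any claim that something is new, unique, unknown or untested is made for them only; others in the source may bear on it.

Compound 1 `COc1cc2c(/C=C3/C(=O)N(C)c4ccccc43)c(Cl)n(C)c2cc1C`: 14100 nM
Compound 2 `COc1cc2c(/C=C3/C(=O)N(C)c4ccc(O)cc43)c(Cl)n(C)c2cc1C`: 7410 nM
Compound 3 `COc1cc2c(/C=C3/C(=O)N(C)c4ccccc43)c[nH]c2cc1C`: 74100 nM

Of the compounds shown here, three have been measured in a functional assay on cells (Melanoma cell, Homo sapiens) for inhibition, with a stated time of 48 h; a higher number here means a weaker inhibitor of growth, a lower number a stronger inhibitor of growth. Compound 1 `COc1cc2c(/C=C3/C(=O)N(C)c4ccccc43)c(Cl)n(C)c2cc1C` gives 14100 nM in this assay. Compound 2 `COc1cc2c(/C=C3/C(=O)N(C)c4ccc(O)cc43)c(Cl)n(C)c2cc1C` differs from it by one change, (hydroxy in place of hydrogen on an aromatic carbon), and gives 7410 nM; the step of a 1.9-fold lower number from compound 1 to compound 2 (0.28 log units; within the scatter) is a small one. Compound 3 `COc1cc2c(/C=C3/C(=O)N(C)c4ccccc43)c[nH]c2cc1C` gives 74100 nM in this assay, the highest number of the three; the difference between its core and the core of compound 1 is not broken down here.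

Compound 4 `COc1cc2c(/C=C3/C(=O)N(C)c4ccc(O)cc43)c[nH]c2cc1C` is not yet measured. It stands to compound 3 as compound 2 stands to compound 1: the change is hydroxy in place of hydrogen on an aromatic carbon, the same kind of change as hydroxy in place of hydrogen on an aromatic carbon, made on the core of compound 3. Among the measured compounds shown here, the only guide to its size is the single earlier step of a 1.9-fold lower number from compound 1 to compound 2 (0.28 log units; within the scatter), and that step was within the scatter, so little movement is expected. On that basis compound 4 is expected to give 40000 nM in this assay, with a range from 15000 nM to 100000 nM. This estimate means a step of a 1.9-fold lower number from compound 3 to compound 4 (0.27 log units; within the scatter), resting on one precedent from one pair and on the high number of compound 3, 74100 nM, as the starting point.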

Compound 4, concentration for total growth inhibition: 15100 nM
Beside the measured number, compound 4's estimate is 2.6-fold (0.42 log units) above it; the range from low to high includes it.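

In this assay, hydroxy in place of hydrogen on an aromatic carbon of the core of compound 3 gives a 4.9-fold lower number from compound 3 to compound 4 (0.69 log units; beyond the scatter) and so moves the number by more than the usual scatter. Set beside the same change on the core of compound 1, the two steps point the same way and cannot be told apart in size: the same change on two cores in this assay, a 1.9-fold lower number (0.28 log units; within the scatter) from compound 1 to compound 2 and a 4.9-fold lower number (0.69 log units; beyond the scatter) from compound 3 to compound 4, 2.6-fold (0.41 log units) apart, within the scatter of two such steps. Among the compounds shown here, this supports carrying the change between these two cores as a modest lowering at most, but it rests on only two pairs, one of which has a step within the scatter, so it shows neither a fixed size for the change nor a real dependence of that size on the core, and it says nothing about any other core.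

The compounds shown leave open whether the hydroxy itself matters at this place, or whether a methoxy, a fluorine or an amine in place of the same hydrogen would give a similar step on either core. They also leave open whether a step of this size would hold in cells other than those of this single assay.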